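Piperidin-1-yl in place of pyrrolidin-1-yl: an expected dose

A few compounds are considered here, and "the series" means these few. Any claim that something is new, unique, unknown or untested is made for them only; others in the source may bear on it.

In a functional assay on the whole organism for inhibition, with Mus musculus as the target (on this read-out higher numbers stand for an effect only at larger amounts of compound and lower numbers for an effect already at smaller amounts), compound 1 `CCCCNC(=O)Nc1cccc2c1CN(C)CC2c1ccccc1` gives about 40 mg/kg, and compound 2 `CN1Cc2c(NC(=O)CN3CCCC3)cccc2C(c2ccccc2)C1` gives 39 mg/kg. These two numbers lie within the scatter of each other, so compound 2 cannot be ranked against compound 1. The next compound, compound 3 `CN1Cc2c(NC(=O)CN3CCCCC3)cccc2C(c2ccccc2)C1`, differs from compound 2 in one place: piperidin-1-yl stands in place of pyrrolidin-1-yl on a saturated chain carbon bound to a carbonyl carbon (piperidin-1-yl in place of pyrrolidin-1-yl on a saturated chain carbon bound to a carbonyl carbon). For the measured compounds named here, only one measured step offers any guide. It put (pyrrolidin-1-yl)methyl in place of butylamino on a carbonyl carbon, and it came out as a 1.0-fold lower number from compound 1 to compound 2 (0.01 log units; within the scatter), within the scatter. Going by the values given here, that step does not test the ring swap directly, and no measured pair does. Still, a change of side chain on this carbonyl left the number in place, so no shift beyond the scatter is expected in this assay from this smaller edit. The expected change is a 1.0-fold higher number from compound 2 to compound 3 (0.01 log units; within the scatter). For compound 3 the estimated dose is 40 mg/kg, with an expected range from 20 mg/kg to 80 mg/kg.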

Compound 3, dose for half-maximal effect: about 65 mg/kg
Compound 3: middle estimate off by 1.6-fold (0.21 log units), on the low side; measured number inside the range.
By their numbers in this assay, from the lowest: compounds 2, 1 and 3 (each within the scatter of the next).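

In this assay, for the compounds shown here, the swap of pyrrolidin-1-yl for piperidin-1-yl, on a saturated chain carbon bound to a carbonyl carbon, gives a 1.7-fold higher number from compound 2 to compound 3 (0.22 log units; within the scatter) and is the first direct test of ring size at this place: going from a five-membered to a six-membered ring does not separate the two compounds. The comparison with the open-chain compound gives a 1.6-fold higher number from compound 1 to compound 3 (0.21 log units; within the scatter) and likewise leaves the two unseparated, so butylamino, (pyrrolidin-1-yl)methyl and (piperidin-1-yl)methyl on this carbonyl all sit within the scatter of one another in this small set, and none of the three can be ranked above the others. No measurement is at hand that explains the result or points to a cause for it.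

The compounds shown leave open whether any group on this carbonyl can move the dose clearly beyond the scatter, since every step so far stays inside it. A morpholin-4-yl ring, a piperazin-1-yl ring or a small open amine such as dimethylamino in this place would show whether a further ring atom or an opened ring changes the picture.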